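Chain carbamate in place of methoxy on the shared core

The source may report more compounds than this note shows. Statements on the series, on what has been measured and on what is new or still open speak of the compounds shown alone.

Compound 3 `COCCOc1cc2c(-n3nc(-c4ccccn4)nc3N)ncnc2cc1OC` gives 1200 nM in an assay on MCF7 cells for inhibition of Serine-protein kinase ATM (Homo sapiens), read by immunofluorescence, with a stated time of 1 h; on this read-out lower numbers stand for stronger inhibition and higher numbers for weaker inhibition. This is the lowest of the three numbers shown, though compound 2 `COc1cc2nc(N)nc(-n3nc(-c4ccccn4)nc3N)c2cc1OC` with 2100 nM and compound 1 `COCCOc1cc2ncnc(-n3nc(-c4ccccn4)nc3N)c2cc1OCCOC` with 2300 nM both lie within the scatter of it, so no ordering among the three is secure. Among the compounds with values here, the one single-place step measured, a 1.9-fold lower number from compound 1 to compound 3 (0.28 log units; within the scatter), concerns the chain on this same aromatic oxygen and stayed within the scatter.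

Compound 4 `COc1cc2ncnc(-n3nc(-c4ccccn4)nc3N)c2cc1OCCCNC(=O)OCC(C)(C)C` differs from compound 3 in one place: ((neopentyloxycarbonyl)amino)methyl in place of methoxy on a saturated chain carbon, two bonds along the chain from an oxygen on an aromatic ring. Within the data shown here, the change is larger than anything measured so far, and the only step that bears on it is the one from compound 1 to compound 3, which was within the scatter. Compound 4 is therefore expected to sit close to compound 3, with an estimated step of a 1.2-fold lower number from compound 3 to compound 4 (0.08 log units; within the scatter) and no direction that the data support beyond the scatter. The estimate for compound 4 in this assay is 1000 nM, with a range from 300 nM to 3500 nM reflecting the untested size of the new group.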

Compound 4, half-maximal inhibitory concentration: 1900 nM
Compound 4: the middle estimate sits 1.9-fold (0.28 log units) below what was measured; low and high end bracket the measured number.
By their numbers in this assay, from the lowest: compounds 3, 4, 2 and 1 (each within the scatter of the next).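

In this assay the change gives a 1.6-fold higher number from compound 3 to compound 4 (0.20 log units; within the scatter) and so stays within the scatter. The earlier step on this chain swapped only hydrogen and methoxymethyl, whereas this one puts 3-((neopentyloxycarbonyl)amino)propyl in place of 2-methoxyethyl, with 10 heavy atoms entering for 2 and a hydrogen-bond donor and a carbonyl added, and the number still cannot be told apart from that of compound 3. No supporting measurement bears on why this is so.

On these data alone, whether a free primary amine or a carboxylic acid at the end of this chain would move the number beyond the scatter remains open. So does whether a smaller carbamate, such as the methyl carbamate, or a longer chain carrying the neopentyl carbamate would read any differently from compound 4.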